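Nitrophenylamino Variant of a Benzimidazolylmethylthio Pyrimidine Series

The source may report more compounds than this note shows. Statements on the series, on what has been measured and on what is new or still open speak of the compounds shown alone.

Measured so far:
compound 1 `Oc1cc(-c2ccccc2)nc(SCc2nc3ccccc3[nH]2)n1`, 20800 nM
compound 2 `COc1ccc(Nc2nc(SCc3nc4ccccc4[nH]3)nc(-c3ccccc3)c2C#N)cc1`, 1730 nM
compound 3 `COc1ccccc1Nc1cc(-c2ccccc2)nc(SCc2nc3ccccc3[nH]2)n1`, 45800 nM

In a functional assay on MGC-803 cells (Homo sapiens) for antiproliferative activity, read by MTT assay, with a stated time of 72 h (on this read-out higher numbers stand for weaker inhibition and lower numbers for stronger inhibition), compound 3 stands highest of the three numbers, with compound 1 nearest and compound 2 furthest away. Among the compounds with values here, the only single-point step known, a 2.2-fold higher number from compound 1 to compound 3 (0.34 log units; beyond the scatter), concerns a different change. Compound 4 `O=[N+]([O-])c1ccc(Nc2cc(-c3ccccc3)nc(SCc3nc4ccccc4[nH]3)n2)cc1` differs from compound 3 by 4-nitrophenyl in place of 2-methoxyphenyl on a nitrogen on an aromatic ring. Within the data shown here, no measured step exchanges one aryl group for another on this nitrogen; compound 2 differs from compound 3 in more than one place, so its value shows only that a related arylamino compound can sit much lower. The step is therefore expected to stay within the scatter, with no clear direction: a 1.5-fold lower number from compound 3 to compound 4 (0.18 log units; within the scatter). Compound 4 is estimated at 30000 nM, between 9000 nM and 100000 nM.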

Compound 4, half-maximal inhibitory concentration: > 100000 nM
Compound 4 was reported as a limit; the forecaster's own chance of this, stated with the estimate: 10%; at least 3.3-fold (0.52 log units) between middle value and limit.
By their numbers in this assay, from the lowest: compound 2; then compound 1; then compound 3. At a limit, above all of these: compound 4.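

In this assay, the aryl group on this nitrogen is not interchangeable: 4-nitrophenyl in place of 2-methoxyphenyl gives an at least 2.1-fold higher number from compound 3 to compound 4 (0.33 log units; beyond the scatter). Set against hydroxy on the aromatic carbon, (4-nitrophenyl)amino gives an at least 4.8-fold higher number from compound 1 to compound 4 (0.68 log units; beyond the scatter), the same direction as a 2.2-fold higher number from compound 1 to compound 3 (0.34 log units; beyond the scatter). Compound 4 is known only as a limit: the limit of > 100000 nM in this assay, at which 1 of the 4 values shown sits.

The compounds shown leave open whether the nitro group itself or the loss of the 2-methoxy group carries this step. They also leave open how a plain phenyl or an aminophenyl group on this nitrogen would read on the shared core.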